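Bromo for Methyl on a Weak Growth Inhibitor

This account rests on a few compounds, and the source may have more. Where it says the series, first, only, none or still open, it means among the compounds named here.

Of the compounds shown here, two sharing the same core have been tested in a functional assay on T47D cells (Homo sapiens) for inhibition, read by sulforhodamine B assay, with a stated time of 48 h; on this read-out higher numbers stand for weaker inhibition of growth and lower numbers for stronger inhibition of growth. Compound 1 `COC(=O)[C@@]1(C)CCC=C2[C@@H]1CC[C@@H](C)[C@]2(C)Cc1c[nH]c2ccc(Br)cc12` gives 16000 nM in this assay. Compound 2 `COC(=O)[C@@]1(C)CCC=C2[C@@H]1CC[C@@H](C)[C@]2(C)Cc1c(C)[nH]c2ccc(C)cc12` gives 31000 nM in this assay, and the gap between compound 2 and compound 1 lies within the usual scatter of repeated measurements, so the two numbers cannot be told apart; both point to weak inhibition of growth.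

Compound 3 `COC(=O)[C@@]1(C)CCC=C2[C@@H]1CC[C@@H](C)[C@]2(C)Cc1c(C)[nH]c2ccc(Br)cc12` has not yet been measured in this assay. It differs from compound 2 in one place: bromo in place of methyl on an aromatic carbon. Going by the values given here, no measured pair in this set isolates that change, so its size is not known from a direct comparison. What the data do show is that compound 1, which carries bromo at the same place, gives 16000 nM, a number within the scatter of compound 2.

On that ground a step from compound 2 to compound 3 of about a 1.6-fold lower number from compound 2 to compound 3 (0.19 log units; within the scatter) is expected, with no direction established beyond the scatter. Compound 3 is therefore estimated at 20000 nM in this assay, with a range from 8000 nM to 60000 nM.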

Compound 3, concentration for 50% growth inhibition: 16000 nM
Estimate against measurement, compound 3: 1.3-fold (0.10 log units) above; measured number inside the range.
By their numbers in this assay, from the lowest: compounds 1, 3 and 2 (each within the scatter of the next).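

In this assay, the exchange at this position now has a direct reading: bromo in place of methyl on an aromatic carbon of the six-membered aromatic ring of carbon only gives a 1.9-fold lower number from compound 2 to compound 3 (0.29 log units; within the scatter), so this swap cannot be told apart from no change. The other single change, methyl in place of hydrogen on an aromatic carbon, can now be read as well and gives no change at the digits printed from compound 1 to compound 3 (within the scatter). Neither step takes these compounds out of weak inhibition of growth, and nothing at hand offers a reason for how little these numbers differ.

On these data alone, all three compounds carry either bromo or methyl at this position, so it remains open whether a different group there, such as methoxy, an amine or a carboxylic acid, would give a step beyond the scatter in this assay. The methyl ester stays the same throughout, which also leaves open what a carboxylic acid or an amide in its place would give.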